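This account rests on a few compounds, and the source may have more. Where it says the series, first, only, none or still open, it means among the compounds named here.

In a functional assay on K562 cells (Homo sapiens) for cytotoxicity, read by trypan blue exclusion, with a stated time of 96 h (a lower number here means a stronger inhibitor, a higher number a weaker inhibitor), compound 1 (`COc1ccc(NS(=O)(=O)/C=C/c2c(OC)cc(OC)cc2OC)cc1`) gives 75 nM, compound 2 (`COc1cc(OC)c(/C=C/S(=O)(=O)Nc2ccc(OC)c(N)c2)c(OC)c1`) gives 3 nM and compound 3 (`COC(=O)C(C)(C)Nc1cc(NS(=O)(=O)/C=C/c2c(OC)cc(OC)cc2OC)ccc1OC`) gives 300 nM, the highest of the three numbers. Compound 4 (`COC(=O)C(Nc1cc(NS(=O)(=O)/C=C/c2c(OC)cc(OC)cc2OC)ccc1OC)c1ccc(F)cc1`) changes the group on the nitrogen of compound 3: (4-fluorophenyl)(methoxycarbonyl)methyl in place of 1-(methoxycarbonyl)-1-methylethyl on a nitrogen on an aromatic ring. For the measured compounds named here, two measured steps bear on this nitrogen: a 100-fold higher number from compound 2 to compound 3 (2.00 log units; beyond the scatter), and a 4.0-fold higher number from compound 1 to compound 3 (0.60 log units; beyond the scatter). Both show that the read-out responds to substitution at this place, the first by a large step and the second by a modest one. Neither tests the entering 4-fluorophenyl ring, so the data give no direction, and no shift beyond the scatter is expected. The expected change is a 1.5-fold lower number from compound 3 to compound 4 (0.18 log units; within the scatter). Compound 4 is estimated at 200 nM, with an expected range from 40 nM to 1000 nM.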

Compound 4, half-maximal inhibitory concentration: 2500 nM
Compound 4: middle estimate off by 13-fold (1.10 log units), on the low side; the measured number lies above the stated range.
By their numbers in this assay, from the lowest: compound 2; then compound 1; then compound 3; then compound 4.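

For the compounds shown here, at the nitrogen on the aromatic ring, an 8.3-fold higher number from compound 3 to compound 4 (0.92 log units; beyond the scatter) in this assay shows that the two ester-bearing groups are not interchangeable, a difference among substituents that the earlier steps could not show. Against the free amine, the entering (4-fluorophenyl)(methoxycarbonyl)methyl group gives an 830-fold higher number from compound 2 to compound 4 (2.92 log units; beyond the scatter) as the largest step in the series. Nothing available accounts for this loss.

Open, as far as these compounds go, is whether the 4-fluorophenyl ring or the enlarged group as a whole drives the change. Also open, from the compounds shown here alone, is how a carboxylic acid in place of the methyl ester, or an unsubstituted phenyl ring, would read out at this nitrogen.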